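Swapping trifluoromethoxy for chloro in a small series

The compounds below may be only part of what the source reports. "The series", "measured", "known", "first", "only" and "open" are said of these compounds alone.

In a functional assay on HL-60 cells (Homo sapiens) for cytotoxicity, read by WST assay, with a stated time of 48 h (a lower number here means that less compound is needed, a higher number that more compound is needed for the effect), three compounds built on one shared core have been measured so far. Compound 1 (`O=C1OC[C@H](Cc2ccccc2)[C@H]1Cc1ccccc1O`) reads 83000 nM there. Compound 2 (`O=C1OC[C@H](Cc2ccccc2)[C@H]1Cc1ccccc1C(F)(F)F`) reads 37000 nM there. Compound 3 (`O=C1OC[C@H](Cc2ccccc2)[C@H]1Cc1cccc(OC(F)(F)F)c1`) reads 34000 nM there, which stands level with compound 2 within the scatter and lower than the number of compound 1.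

Compound 4 (`O=C1OC[C@H](Cc2ccccc2)[C@H]1Cc1cccc(Cl)c1`) is still unmeasured and differs from compound 3 by a single change (chloro in place of trifluoromethoxy on an aromatic carbon) that puts chloro in place of trifluoromethoxy on an aromatic carbon. Going by the values given here, no measured pair makes this swap, so the guidance is indirect. Among the compounds with values here, the only measured step, trifluoromethyl in place of hydroxy on an aromatic carbon, gave a 2.2-fold lower number from compound 1 to compound 2 (0.35 log units; beyond the scatter) and bears on the new change only loosely. Even that step, involving other groups, was modest in size. Compound 2 and compound 3 also carry different groups, yet their values lie within the scatter of each other. No step beyond the scatter is therefore expected, and the estimate means a 1.1-fold higher number from compound 3 to compound 4 (0.05 log units; within the scatter) as the expected move. For compound 4 the expected value is 38000 nM with an estimated range from 17000 nM to 85000 nM on this read-out.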

Compound 4, half-maximal effective concentration: 36000 nM
Estimate against measurement, compound 4: 1.1-fold (0.02 log units) above, and the stated range covers the measured number.
By their numbers in this assay, from the lowest: compounds 3, 4 and 2 (each within the scatter of the next); then compound 1.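

In this assay, the exchange of trifluoromethoxy for chloro gives a 1.1-fold higher number from compound 3 to compound 4 (0.02 log units; within the scatter), so a group of 5 heavy atoms with 1 hydrogen-bond acceptor and a single chlorine atom with 0 read alike on this aromatic carbon, meta to a large group. The other new step, 3-chlorophenyl in place of 2-hydroxyphenyl, gives a 2.3-fold lower number from compound 1 to compound 4 (0.36 log units; beyond the scatter), a modest move beyond the scatter, but it alters both the group and where it sits on the ring, and this one comparison cannot separate the two. Nothing available accounts for the matching readings of compound 3 and compound 4, or for the step from the hydroxy compound.

From the compounds shown here alone, whether an amine, a carboxylic acid or a longer chain on this same aromatic carbon would also read like chloro and trifluoromethoxy remains open, as does whether chloro and hydroxy would differ if they sat on the same ring carbon. Going by these compounds, these numbers also come from a single cell line, so it is unknown whether the match between the two groups holds in any other cells.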